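Swapping a nitrile for fluorine on a weakly active scaffold

The source may hold more compounds than are shown below. What is called first, only, known or untested is meant among the compounds shown, and "the series" means these compounds.

Compound 1, `N#Cc1ccccc1COc1ccc([C@H]2CC[C@@H](C(N)=O)N2)cc1`, in an assay on HEK293 cells for inhibition of sodium channel protein type 3 subunit alpha (Homo sapiens), read by electrophysiology, with a stated time of 3.5 min; on this read-out higher numbers stand for weaker inhibition and lower numbers for stronger inhibition: > 63000 nM, a limit of the assay.
Compound 2, `N#Cc1ccc(COc2ccc([C@H]3CC[C@@H](C(N)=O)N3)cc2)cc1`, in this assay: > 63000 nM, a limit of the assay.

In this assay compound 2 gives > 63000 nM, which is only a limit and not a measured number. The step that the two limits leave unreadable from compound 1 to compound 2 is therefore unreadable. Compound 3, `NC(=O)[C@@H]1CC[C@H](c2ccc(OCc3cccc(F)c3)cc2)N1`, differs from compound 2 by 3-fluorophenyl in place of 4-cyanophenyl on a saturated chain carbon bound to an oxygen on an aromatic ring. For the measured compounds named here, the only evidence available is the limit of > 63000 nM in this assay, at which 2 of the 2 values shown sit, so no direction of change can be drawn from it. Compound 3 is expected to give 63000 nM, within a range from 10000 nM to 300000 nM, most probably again reported as a limit. The expected step of a number no higher from compound 2 to compound 3 (the limit leaves the size open) is accordingly estimated as none beyond the scatter.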

Compound 3, half-maximal inhibitory concentration: > 100000 nM
Compound 3 ended at the assay's limit; the forecaster's own chance of this, stated with the estimate: 75%; at least 1.5-fold (0.20 log units) between middle value and limit.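

Compound 3 gives > 100000 nM in this assay, again a limit of the assay. For the compounds shown here, with compound 1, compound 2 and compound 3 all reported as limits, no step among them can be read. From the compounds shown here alone, whether swapping these groups changes inhibition at all, and by how much, remains open.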